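Notes on the step from compound 2 to compound 4

The source may report more compounds than this note shows. Statements on the series, on what has been measured and on what is new or still open speak of the compounds shown alone.

Compound 1 `Nc1scc(CN2CCN(c3ccc([N+](=O)[O-])cc3)CC2)c1C(=O)c1ccc(Cl)cc1` gives -17% in a functional assay on CHO cells with adenosine receptor A1 (Homo sapiens) as the target, read by cAMP accumulation and immunoassay, with a stated time of 6 min, tested at 10 uM; a higher number here means a weaker effect of the compound at the concentration tested, a lower number a stronger effect. Compound 2 `Nc1scc(CN2CCN(c3ccccc3C(F)(F)F)CC2)c1C(=O)c1ccc(Cl)cc1` gives -60% in this assay, and compound 3 `Nc1scc(CN2CCN(c3ccc(C(F)(F)F)cc3)CC2)c1C(=O)c1cccc(C(F)(F)F)c1` gives -47%. Compound 2 thus gives the lowest number of the three, its gaps to compound 3 and to compound 1 both beyond the scatter. Within the data shown here, the only measured step at the ring on the amine nitrogen, a number 43 percentage points lower from compound 1 to compound 2 (beyond the scatter), shows that this group carries weight. Compound 4 `Nc1scc(CN2CCN(c3ccccc3F)CC2)c1C(=O)c1ccc(Cl)cc1` differs from compound 2 by fluoro in place of trifluoromethyl on an aromatic carbon. Among the measured compounds shown here, no measured step tests trifluoromethyl against fluoro, so the expectation rests on compound 2 alone and is loose. The expected step is a number 25 percentage points higher from compound 2 to compound 4 (beyond the scatter). Compound 4 is estimated at -35%, range -65% to -5%.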

Compound 4, a percentage reported as activity, at one concentration (the size of the read-out at that concentration, not a potency): -15%
The estimate for compound 4 lay 20 percentage points below the measured number, and the stated range covers the measured number.
By their numbers in this assay, from the lowest: compound 2; then compound 3; then compounds 1 and 4 (each within the scatter of the next).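

Fluoro in place of trifluoromethyl on this aromatic carbon gives a number 45 percentage points higher from compound 2 to compound 4 (beyond the scatter) in this assay, so the group at this place carries weight, not only the ring on the amine nitrogen. With 2-fluorophenyl in place of 4-nitrophenyl, the result is a number 2 percentage points higher from compound 1 to compound 4 (within the scatter), so a fluoro at this place does not reproduce the low number of compound 2. Nothing at hand gives a reason for either step. On these data alone, whether chloro, methoxy or an amine at this place would read closer to compound 2 or to compound 4 remains open.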